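Cytotoxicity notes on a cyclopentenone series

The compounds below may be only part of what the source reports. "The series", "measured", "known", "first", "only" and "open" are said of these compounds alone.

Measured so far:
- compound 1 `COc1ccc(C2=C(c3cc(OC)c(OC)c(OC)c3)C(=O)CC2O[SiH2]C(C)(C)C)cc1OC` — in an ADME assay on HEp-2 cells (Homo sapiens) for cytotoxicity, read by MTT assay, with a stated time of 72 h (a lower number here means a stronger inhibitor, a higher number a weaker inhibitor), compound 1 reaches only the assay limit, > 100 ug/mL.
- compound 2 `COc1cc(C2=C(c3cc(C)c(OC)c(C)c3)C(O)CC2=O)cc(OC)c1OC` — in this assay compound 2 likewise gives only a limit, > 100 ug/mL.

Compound 1 stands at the limit and nowhere more precise: no number is known for it, and the same holds for compound 2, so that (the limit of > 100 ug/mL in this assay, at which 2 of the 2 values shown sit). Going by the values given here, no step between measured compounds can be drawn from two limits, and no ordering of compound 1 against compound 2 is possible.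

Compound 3 `COc1ccc(OC)c(C2=C(c3cc(OC)c(OC)c(OC)c3)C(=O)CC2O[SiH2]C(C)(C)C)c1` is the next candidate. It differs from compound 1 by 2,5-dimethoxyphenyl in place of 3,4-dimethoxyphenyl on a double-bonded ring carbon. Among the compounds with values here, two limits give no measured step to lean on, so the expectation for this assay is a step of no size beyond the scatter, in no particular direction. Compound 3 is therefore expected to come back at or near the limit again, with an estimated value of 100 ug/mL, between 50 ug/mL and 200 ug/mL. The step this estimate implies, a number no higher from compound 1 to compound 3 (the limit leaves the size open), is expected to be none beyond the scatter.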

Compound 3, half-maximal inhibitory concentration: 19 ug/mL
Estimate against measurement, compound 3: 5.3-fold (0.72 log units) above; the measured number lies below the stated range.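

This position on a double-bonded ring carbon of the five-membered ring is not indifferent to how the two methoxy groups are arranged in this assay: 2,5-dimethoxyphenyl in place of 3,4-dimethoxyphenyl gives an at least 5.2-fold lower number from compound 1 to compound 3 (0.72 log units; beyond the scatter). The two groups have the same atoms and the same counts of hydrogen-bond donors and acceptors, so this step tracks a rearrangement of the aryl group alone, with nothing added to or removed from the compound. Compound 3 is also the only compound shown with a true number rather than a limit, and it gives the series its first point for comparison: the limit of > 100 ug/mL in this assay, at which 2 of the 3 values shown sit.

As far as these compounds go, the full size of the step stays open, as does any step to compound 2, since neither can be read beyond what is printed. From the compounds shown here alone, it is also open whether the result depends on the two methoxy groups themselves or would persist with 2,5-dihydroxyphenyl or 2,5-diethoxyphenyl at this position, or with a free hydroxyl in place of the silyl ether on the neighbouring ring atom.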